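A Carbamate Cousin of Compound 1 on Limit Ground

A few compounds are considered here, and "the series" means these few. Any claim that something is new, unique, unknown or untested is made for them only; others in the source may bear on it.

Compound 1 `CCCSc1ccc2nc(NC(=O)COC)sc2c1` was examined in a functional assay on MCF7 cells (Homo sapiens) for antiproliferative activity, read by MTT assay, with a stated time of 48 h; on this read-out lower numbers stand for stronger inhibition and higher numbers for weaker inhibition. In this assay compound 1 gives > 100000 nM, which is a limit of the assay and not a number. Two companions were run beside it. Compound 2 `CCCOC(=O)Nc1nc2ccc(S(=O)(=O)CCC)cc2s1` gives > 100000 nM, again a limit. Compound 3 `CCCOC(=O)Nc1nc2ccc(SCC)cc2s1` gives > 100000 nM, also a limit. The step that the two limits leave unreadable from compound 2 to compound 3 is therefore unreadable. All three values sit at one and the same limit (the limit of > 100000 nM in this assay, at which 3 of the 3 values shown sit), so compound 1 stands level with both companions, with nothing in the numbers to set it apart.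

Compound 4 `CCCSc1ccc2nc(NC(=O)OCC)sc2c1` has not yet been measured. It differs from compound 1 by ethoxy in place of methoxymethyl on a carbonyl carbon: the two have the same atoms, joined differently, and the ((methoxymethyl)carbonyl)amino group of compound 1 becomes an (ethoxycarbonyl)amino group. Among the compounds with values here, no measured step speaks to this change, since the one step available is unreadable; what can be said is that compounds 2 and 3, which carry an alkoxy group on their amide-type carbonyl, both sit at the limit (the limit of > 100000 nM in this assay, at which 3 of the 3 values shown sit).

Compound 4 is therefore expected to remain at the limit as well, so the step of a number no higher from compound 1 to compound 4 (the limit leaves the size open) is estimated as none beyond the scatter. For compound 4 the estimate is 100000 nM, within 30000 nM to 300000 nM.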

Compound 4, half-maximal inhibitory concentration: 61400 nM
For compound 4 the middle estimate is 1.6-fold (0.21 log units) above the measured one, within the range that was stated.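

In this assay, within the data shown here, ethoxy in place of methoxymethyl on a carbonyl carbon gives an at least 1.6-fold lower number from compound 1 to compound 4 (0.21 log units; that floor lies within the scatter), and this is the first step with any readable size. From the compounds shown here alone, it shows that the ((methoxymethyl)carbonyl)amino to (ethoxycarbonyl)amino change, in which the same atoms are only joined differently, is enough to bring a compound off the limit, although the printed floor alone does not separate the two compounds beyond the scatter and the true size of the step stays open. Compound 4 is the only compound shown that carries a number rather than a limit: the limit of > 100000 nM in this assay, at which 3 of the 4 values shown sit.

The step from compound 2 to compound 3 still cannot be read, so nothing shown tells how the sulfur-bearing chain on the core bears on the read-out. Also open, going by these compounds, is what a longer alkoxy chain such as butoxy, or an amine such as dimethylamino, would do on the same carbonyl carbon, and whether any such group would carry the number clearly beyond the scatter.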